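The source may report more compounds than this note shows. Statements on the series, on what has been measured and on what is new or still open speak of the compounds shown alone.

Three compounds of the series have numbers in a functional assay on U-87MG ATCC cells (Homo sapiens) for antiproliferative activity, read by MTT assay, with a stated time of 48 h; a higher number here means a weaker inhibitor, a lower number a stronger inhibitor. Compound 1 `COc1ncc(-c2ccc3nc(NC(C)=O)nn3c2)cc1NS(=O)(=O)c1ccc(F)cc1F` gives 2000 nM. Compound 2 `COc1ncc(-c2ccc3nc(NC(=O)C4CC4)nn3c2)cc1NS(=O)(=O)c1ccc(F)cc1` gives 4850 nM, the second highest of the three; its nearest neighbour is compound 3 `O=C(Nc1nc2ccc(-c3cnc(Cl)c(NS(=O)(=O)c4ccc(F)cc4)c3)cn2n1)C1CC1`, which gives 11000 nM, and the step of a 2.3-fold higher number from compound 2 to compound 3 (0.36 log units; beyond the scatter) comes from chloro in place of methoxy on an aromatic carbon. Compound 4 `CCOC(=O)CNc1nc2ccc(-c3cnc(OC)c(NS(=O)(=O)c4ccc(F)cc4)c3)cn2n1` is not yet measured; it differs from compound 2 by (ethoxycarbonyl)methyl in place of cyclopropylcarbonyl on a nitrogen on an aromatic ring. Among the compounds with values here, no measured step touches this nitrogen, so the only scale available is the modest step of a 2.3-fold higher number from compound 2 to compound 3 (0.36 log units; beyond the scatter) at another place. The expected step is a 1.4-fold higher number from compound 2 to compound 4 (0.16 log units; within the scatter), toward a higher number, of a size not far beyond that one. Compound 4 is therefore estimated at 7000 nM, within 2500 nM to 20000 nM.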

Compound 4, half-maximal inhibitory concentration: 7940 nM
Compound 4: middle estimate off by 1.1-fold (0.05 log units), on the low side; measured number inside the range.
By their numbers in this assay, from the lowest: compound 1; then compounds 2, 4 and 3 (each within the scatter of the next, the first and the last beyond it).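

The nitrogen on an aromatic ring now has a measured step of its own: in this assay the swap to (ethoxycarbonyl)methyl from cyclopropylcarbonyl gives a 1.6-fold higher number from compound 2 to compound 4 (0.21 log units; within the scatter) and so stays within the scatter. At this position, the amide carbonyl and the three-membered ring of compound 2 can therefore both be replaced without a step beyond the scatter. No measurement here bears on why this is so.

From the compounds shown here alone, the free carboxylic acid in place of the ethyl ester remains open, as do a simple amine and a longer chain on this nitrogen. Whether the step holds with chloro in place of methoxy, as in compound 3, is also unknown.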